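The compounds below may be only part of what the source reports. "The series", "measured", "known", "first", "only" and "open" are said of these compounds alone.

The series rests on a shared core, seen in compound 1, `COc1cc2c(C(=O)N3CCCCCC3)cn(C(C)C)c(=O)c2cc1OC`, which carries an isopropyl on its aromatic nitrogen and an azepane amide. In an assay on CHO cells for antagonist activity at lysophosphatidic acid receptor 5 (Rattus norvegicus), read by cAMP accumulation, with a stated time of 30 min (a lower number here means a stronger inhibitor, a higher number a weaker inhibitor), compound 1 gives only a limit of > 30000 nM. A second member, compound 2, `CCCCCCN(C)C(=O)c1cn(-c2ccc(OCC)cc2)c(=O)c2cc(OC)c(OC)cc12`, also reaches no measurable number: in this assay compound 2 gives a limit of > 10000 nM. So both measured values are limits the limit of > 10000 nM in this assay, at which 1 of the 2 values shown sits, and (the limit of > 30000 nM in this assay, at which 1 of the 2 values shown sits), and no step between measured compounds can be drawn; compound 1 stands at a limit, with the other value shown also a limit.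

Compound 3, `CCN1CCc2ccc(-n3cc(C(=O)N4CCCCCC4)c4cc(OC)c(OC)cc4c3=O)cc21`, keeps the azepane amide of compound 1 but changes the group on the aromatic nitrogen: 1-ethyl-2,3-dihydro-1H-indol-6-yl in place of isopropyl on an aromatic nitrogen. Among the measured compounds shown here, with both known values sitting at limits, nothing measured points to a direction, yet the larger group is the one unexplored change, so a gain toward a measurable number is expected, of a size an at least 10-fold lower number from compound 1 to compound 3 (1.00 log units; beyond the scatter), though a third limit remains quite possible. For compound 3 in this assay the estimate is 3000 nM, with a range from 300 nM to 30000 nM.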

Compound 3, half-maximal inhibitory concentration: 110 nM
Beside the measured number, compound 3's estimate is 27-fold (1.44 log units) above it; the whole stated range lies above it.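

Among the compounds shown here, with the azepane amide held constant, putting 1-ethyl-2,3-dihydro-1H-indol-6-yl in place of isopropyl on the aromatic nitrogen gives the first measurable number, and in this assay the change amounts to an at least 270-fold lower number from compound 1 to compound 3 (2.43 log units; beyond the scatter). For the compounds shown here, this size is only a minimum, because compound 1 stands at a limit of the assay and has no exact value: the limit of > 30000 nM in this assay, at which 1 of the 3 values shown sits. The earlier compounds gave no number from which to judge any change, whereas this step shows that the group on this aromatic nitrogen can decide between a limit and a measured inhibitor when the rest of the structure stays the same.

The compounds shown do not reveal which part of the entering group carries the gain, whether its ethyl, its five-membered ring, its ring nitrogen or simply its six-membered aromatic ring. On these data alone, it also remains open how a plain phenyl or a 4-methoxyphenyl would read on the same nitrogen, and whether the gain would survive if a piperidine replaced the azepane in the amide.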